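Ethynyl in place of the ring of compound 3

A few compounds are considered here, and "the series" means these few. Any claim that something is new, unique, unknown or untested is made for them only; others in the source may bear on it.

Measured in a functional assay on KYSE-410 cells (Homo sapiens) for antiproliferative activity, read by MTT assay, with a stated time of 72 h; a higher number here means a weaker inhibitor, a lower number a stronger inhibitor:
Compound 1 `CC(=O)c1ccc(-c2ccc3c(C(=O)Nc4cccc(F)c4)cc(=O)[nH]c3c2)cc1`: > 20000 nM, a limit of the assay
Compound 2 `COc1ccc(-c2ccc3c(C(=O)Nc4cccc(F)c4)cc(=O)[nH]c3c2)cc1`: 18000 nM
Compound 3 `O=C(Nc1cccc(F)c1)c1cc(=O)[nH]c2cc(C3=CCOCC3)ccc12`: 12100 nM

Going by the values given here, compound 3 is one of only two compounds with a number in this assay, and its value lies within the scatter of that of compound 2.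

Compound 4 `C#Cc1ccc2c(C(=O)Nc3cccc(F)c3)cc(=O)[nH]c2c1` has not yet been measured. It differs from compound 3 by one exchange: a group of 2 heavy atoms (2 carbon; no ring) in place of a group of 6 heavy atoms (5 carbon, 1 oxygen; one six-membered non-aromatic ring with 1 hetero atom), on an aromatic carbon. The ethynyl group stands on the aromatic carbon that is meta to a fused ring and para to a fused ring.

Three exchanges on an aromatic carbon bear on this one: an at least 1.1-fold lower number from compound 1 to compound 2 (0.04 log units; that floor lies within the scatter), an at least 1.6-fold lower number from compound 1 to compound 3 (0.21 log units; that floor lies within the scatter) and a 1.5-fold lower number from compound 2 to compound 3 (0.17 log units; within the scatter). All three lie within the scatter, and the first two are only floors.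

On that evidence, no step beyond the scatter is expected in this assay, and the estimated move is a 1.1-fold higher number from compound 3 to compound 4 (0.03 log units; within the scatter). Compound 4 is estimated at 13000 nM, with an expected range of 5000 nM to 25000 nM.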

Compound 4, half-maximal inhibitory concentration: 9700 nM
The estimate for compound 4 lay 1.3-fold (0.13 log units) above the measured number; measured number inside the range.
By their numbers in this assay, from the lowest: compounds 4, 3 and 2 (each within the scatter of the next). At a limit, above all of these: compound 1.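

In this assay, this aromatic carbon takes ethynyl, which has no ring, in place of much larger ring-bearing groups with no change beyond the scatter: a 1.2-fold lower number from compound 3 to compound 4 (0.10 log units; within the scatter), and a 1.9-fold lower number from compound 2 to compound 4 (0.27 log units; within the scatter). Against the 4-acetylphenyl group of compound 1, the same exchange gives an at least 2.0-fold lower number from compound 1 to compound 4 (0.31 log units; beyond the scatter), the only step among these compounds that passes the scatter. Compound 1 stands at a limit of the assay, so that step is a floor and its true size stays unknown: the limit of > 20000 nM in this assay, at which 1 of the 4 values shown sits.

The compounds shown leave open whether an amine, a carboxylic acid or a longer chain on this carbon would move the number beyond the scatter of compound 4. They also leave open whether ethynyl would compare in the same way with a different amide on the shared core.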